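Cyclopropylmethyl on the indole nitrogen of the chloro analog

A few compounds are considered here, and "the series" means these few. Any claim that something is new, unique, unknown or untested is made for them only; others in the source may bear on it.

Among the compounds with values here, compound 2 `Cn1ccc2cc(-c3ccn4c(CC(F)(F)F)cnc4c3C#N)cc(Cl)c21` shows the lowest of the two numbers so far: in a functional assay on CHO cells for agonist activity at metabotropic glutamate receptor 2 (Homo sapiens), read by GTPgammaS binding (a lower number here means that less compound is needed, a higher number that more compound is needed for the effect), compound 2 gives 120 nM. Compound 1 `N#Cc1c(-c2ccc3c(ccn3CC3CC3)c2)ccn2c(CC(F)(F)F)cnc12` differs from it in more than one place; in this assay compound 1 gives 190 nM, within the scatter of compound 2. Compound 3 `N#Cc1c(-c2cc(Cl)c3c(ccn3CC3CC3)c2)ccn2c(CC(F)(F)F)cnc12` carries cyclopropyl in place of hydrogen on a saturated chain carbon bound to an aromatic nitrogen. Within the data shown here, no measured pair isolates this change, so the step from compound 2 to compound 3 is expected to stay within the scatter, with no clear direction: a 1.1-fold higher number from compound 2 to compound 3 (0.03 log units; within the scatter). Compound 3 is therefore estimated at 130 nM in this assay, with a range from 50 nM to 350 nM.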

Compound 3, half-maximal effective concentration: 110 nM
For compound 3 the middle estimate is 1.2-fold (0.07 log units) above the measured one; low and high end bracket the measured number.
By their numbers in this assay, from the lowest: compounds 3, 2 and 1 (each within the scatter of the next).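

Methyl to cyclopropylmethyl can now be read as a single change: a 1.1-fold lower number from compound 2 to compound 3 (0.04 log units; within the scatter) in this assay shows that cyclopropyl in place of hydrogen on a saturated chain carbon bound to an aromatic nitrogen is accommodated without a shift beyond the scatter. Chloro in place of hydrogen on an aromatic carbon is also isolated here, and a 1.7-fold lower number from compound 1 to compound 3 (0.24 log units; within the scatter) again gives no shift beyond the scatter. No supporting data bear on either step.

On these data alone, it remains open how a longer chain or an amine at this place would read. As far as these compounds go, whether any change at either place moves the number beyond the scatter also remains open.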